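A few compounds are considered here, and "the series" means these few. Any claim that something is new, unique, unknown or untested is made for them only; others in the source may bear on it.

Measured so far in a functional assay on A-375 cells (Homo sapiens) for antiproliferative activity, read by MTT assay, with a stated time of 48 h; a higher number here means a weaker inhibitor, a lower number a stronger inhibitor:
compound 1, `CCCCCCc1nc(N)n(CC(=O)Nc2ccccc2)c1-c1ccccc1Br`, gives 5700 nM.
compound 2, `COc1ccc(Cc2nc(N)n(CC(=O)Nc3ccccc3)c2-c2ccccc2Br)cc1`, gives 1400 nM.
compound 3, `CCCCCCc1nc(N)n(CC(=O)Nc2ccc(C)cc2)c1-c1ccccc1Br`, gives 5100 nM.

Compound 3 holds the second highest of the three numbers. Its nearest neighbour is compound 1: the step of a 1.1-fold lower number from compound 1 to compound 3 (0.05 log units; within the scatter) lies within the scatter, so the two compounds cannot be told apart on this read-out. The furthest from it is compound 2, whose number is the lowest of the three, and that gap is beyond the scatter.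

Compound 4, `Cc1ccc(NC(=O)Cn2c(N)nc(Cc3ccccc3)c2-c2ccccc2Br)cc1`, differs from compound 3 in one place: phenyl in place of pentyl on a saturated chain carbon bound to an aromatic carbon. Among the compounds with values here, only one measured step bears on this change, a 4.1-fold lower number from compound 1 to compound 2 (0.61 log units; beyond the scatter), in which a 4-methoxyphenyl replaced the same pentyl at the same place. Compound 4 carries a plain phenyl there, without the methoxy group, so the analogy is partial; the step of a 1.1-fold lower number from compound 1 to compound 3 (0.05 log units; within the scatter) concerns a different place and says nothing about it. On that single precedent a lower number is expected for compound 4, of a size near but somewhat below that step, and the expected step is a 2.8-fold lower number from compound 3 to compound 4 (0.45 log units; beyond the scatter). Compound 4 is therefore estimated at 1800 nM, within a range from 900 nM to 3600 nM.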

Compound 4, half-maximal inhibitory concentration: 2000 nM
Compound 4: middle estimate off by 1.1-fold (0.05 log units), on the low side; measured number inside the range.
By their numbers in this assay, from the lowest: compounds 2 and 4 (each within the scatter of the next); then compounds 3 and 1 (each within the scatter of the next).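

In this assay the change to phenyl gives a 2.6-fold lower number from compound 3 to compound 4 (0.41 log units; beyond the scatter), so an unsubstituted aromatic ring on the saturated chain carbon bound to an aromatic carbon is enough for a step beyond the scatter, with no methoxy group present. Together with a 4.1-fold lower number from compound 1 to compound 2 (0.61 log units; beyond the scatter), this gives two steps in the same direction from pentyl to an aromatic ring, one in the series without the methyl of compound 3 and one in the series with it, so the lower number does not rest on a single background among these four compounds. Nothing given here accounts for why replacing pentyl with phenyl goes with a lower number.

Compound 2 and compound 4 differ in two places, so the methoxy group's own contribution remains unresolved, and it would take the 4-methoxyphenyl and phenyl groups on the same anilide to separate it. Going by these compounds, it also remains open whether a saturated ring such as cyclohexyl would do the same as phenyl, and how an amine or a carboxylic acid on that phenyl would change the number.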